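The compounds below may be only part of what the source reports. "The series", "measured", "known", "first", "only" and "open" are said of these compounds alone.

Two amides on the shared core have numbers in an assay on LtK cells with ATP-sensitive inward rectifier potassium channel 11 (Homo sapiens) as the target (a lower number here means that less compound is needed, a higher number that more compound is needed for the effect), so far. Compound 1 `COc1cccc(C(=O)Nc2c(C(O)(C(F)(F)F)C(F)(F)F)ccc3ccccc23)c1` gives 185 nM in this assay, and compound 2 `O=C(Nc1c(C(O)(C(F)(F)F)C(F)(F)F)ccc2ccccc12)c1ccc(C(F)(F)F)cc1` gives 160 nM. Within the data shown here, the only step between them, a 1.2-fold lower number from compound 1 to compound 2 (0.06 log units; within the scatter), leaves compound 2 with the lowest of the two numbers, though its gap to compound 1 is within the scatter, so no order between them can be read.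

Compound 3 `O=C(Nc1c(C(O)(C(F)(F)F)C(F)(F)F)ccc2ccccc12)c1ccc(Cl)c(Cl)c1` takes the next step: 3,4-dichlorophenyl in place of 4-(trifluoromethyl)phenyl on a carbonyl carbon. Among the measured compounds shown here, the one measured step that bears on it, a swap of the aryl group on the carbonyl carbon from compound 1 to compound 2, moved this assay by a 1.2-fold lower number from compound 1 to compound 2 (0.06 log units; within the scatter), nothing beyond the scatter. On that basis no step beyond the scatter is expected from compound 2 to compound 3 in this assay, an expected change of a 1.1-fold higher number from compound 2 to compound 3 (0.03 log units; within the scatter). Compound 3 is therefore estimated at 170 nM in this assay, with a range from 70 nM to 420 nM.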

Compound 3, half-maximal effective concentration: 194 nM
The estimate for compound 3 lay 1.1-fold (0.06 log units) below the measured number; the range from low to high includes it.
By their numbers in this assay, from the lowest: compounds 2, 1 and 3 (each within the scatter of the next).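

With the 3,4-dichlorophenyl group, the carbonyl carbon now carries three different aryl groups, and this assay does not separate any of them: a 1.2-fold higher number from compound 2 to compound 3 (0.08 log units; within the scatter) and a 1.0-fold higher number from compound 1 to compound 3 (0.02 log units; within the scatter). The earlier pair compared only a methoxy-bearing ring with a trifluoromethyl-bearing ring, whereas this result extends the flat picture to a ring bearing two chlorine atoms, for these three compounds only. Nothing available explains why the three numbers stay so close.

Open is whether this tolerance extends beyond substituted phenyl rings, since the compounds shown carry no amine, carboxylic acid, longer alkyl chain or non-aromatic ring on the carbonyl carbon. Also open, going by these compounds, is how an unsubstituted phenyl ring would compare with the three substituted rings in this assay.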